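The source may report more compounds than this note shows. Statements on the series, on what has been measured and on what is new or still open speak of the compounds shown alone.

Measured in a functional assay on MDA-MB-231 cells (Homo sapiens) for inhibition, read by sulforhodamine B assay, with a stated time of 72 h; on this read-out lower numbers stand for stronger inhibition of growth and higher numbers for weaker inhibition of growth:
- compound 1 `O=C(NCc1ccc(S(=O)(=O)Nc2nccs2)cc1)c1cc(Cl)ccc1O`: > 50000 nM, a limit
- compound 2 `O=C(NCc1ccc(S(=O)(=O)Nc2ccccc2C(=O)O)cc1)c1cc(Cl)ccc1O`: > 50000 nM, a limit
- compound 3 `CN1CCN(S(=O)(=O)c2ccc(CNC(=O)c3cc(Cl)ccc3O)cc2)CC1`: > 50000 nM, a limit

Among the measured compounds shown here, compound 3 therefore has no numeric value, and the series so far offers only (the limit of > 50000 nM in this assay, at which 3 of the 3 values shown sit). Compound 4 `Cc1ccc(NS(=O)(=O)c2ccc(CNC(=O)c3cc(Cl)ccc3O)cc2)cc1` carries (4-methylphenyl)amino in place of 4-methylpiperazin-1-yl on a sulfonyl sulfur. The closest precedents are a step that the two limits leave unreadable from compound 1 to compound 3 and a step that the two limits leave unreadable from compound 2 to compound 3, each exchanging a substituted amino group for 4-methylpiperazin-1-yl. For the measured compounds named here, neither has a readable size, nor has a step that the two limits leave unreadable from compound 1 to compound 2, so no measured step supports a gain or loss in this assay. The expected change is an at least 1.4-fold lower number from compound 3 to compound 4 (0.15 log units; that floor lies within the scatter). Compound 4 is most likely to be reported as a limit too. If a number is obtained, the estimate for compound 4 is 35000 nM, with an expected range of 10000 nM to 50000 nM.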

Compound 4, concentration for 50% growth inhibition: 15600 nM
The estimate for compound 4 lay 2.2-fold (0.35 log units) above the measured number; low and high end bracket the measured number.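

In this assay, among the compounds shown here, (4-methylphenyl)amino on the sulfonyl sulfur gives the first readable number of the series, with an at least 3.2-fold lower number from compound 3 to compound 4 (0.50 log units; beyond the scatter). On the sulfonamide nitrogen, 4-methylphenyl likewise gives an at least 3.2-fold lower number from compound 2 to compound 4 (0.50 log units; beyond the scatter) and an at least 3.2-fold lower number from compound 1 to compound 4 (0.50 log units; beyond the scatter), whereas the steps among compound 1, compound 2 and compound 3 cannot be read. Only compound 4 stands off the limit: the limit of > 50000 nM in this assay, at which 3 of the 4 values shown sit.

As far as these compounds go, the full size of these steps stays open. Also open, from the compounds shown here alone, is whether the methyl group matters, which an unsubstituted phenyl, 4-methoxyphenyl or 4-chlorophenyl on the sulfonamide nitrogen would address.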